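Trading an Acetyl for a Thiophene on Oxygen

This account rests on a few compounds, and the source may have more. Where it says the series, first, only, none or still open, it means among the compounds named here.

In a functional assay on KB cells (Homo sapiens) for cytotoxicity (on this read-out higher numbers stand for weaker inhibition and lower numbers for stronger inhibition), compound 3 (`CC(=O)OC1=CC(=O)c2ccccc2C1=O`) gives 38800 nM and sits level with compound 1 (`O=C(OC1=CC(=O)c2ccccc2C1=O)c1ccccc1`) at 36900 nM within the scatter. Compound 2 (`C=CCOc1ccc2c(c1)C(=O)C=CC2=O`), an ether, reads lower at 10200 nM and so inhibits more strongly. Compound 4 (`O=C1C=C(Oc2cccs2)C(=O)c2ccccc21`) carries thiophen-2-yl in place of acetyl on an oxygen on an unsaturated carbon. Among the measured compounds shown here, the one measured step at that oxygen (a 1.1-fold higher number from compound 1 to compound 3 (0.02 log units; within the scatter)) swapped one ester for another, so it says little about an ether like compound 4. For the measured compounds named here, no measured pair shows this change directly. Going by the values given here, the only hint is that compound 2, also an ether, gives 10200 nM here. A modest step (a 1.9-fold lower number from compound 3 to compound 4 (0.29 log units; within the scatter)) is expected in this assay towards stronger inhibition. Compound 4 is estimated at 20000 nM (range 6000 nM to 60000 nM).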

Compound 4, half-maximal inhibitory concentration: 41500 nM
For compound 4 the middle estimate is 2.1-fold (0.32 log units) below the measured one; measured number inside the range.
By their numbers in this assay, from the lowest: compound 2; then compounds 1, 3 and 4 (each within the scatter of the next).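

In this assay, the step of a 1.1-fold higher number from compound 3 to compound 4 (0.03 log units; within the scatter) shows that an ether bearing thiophen-2-yl on this oxygen reads level with the ester bearing acetyl. With a 1.1-fold higher number from compound 1 to compound 3 (0.02 log units; within the scatter) as well, neither of the two changes at this oxygen moves the number beyond the scatter, even though the second swaps the ester link for an ether link. Still open, on these data alone, is whether an amine or a carboxylic acid carried on this oxygen, or a longer chain, would shift the number beyond the scatter. No measured evidence accounts for this flat result.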